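Working notes: piperidine amide variant of compound 2

The source may report more compounds than this note shows. Statements on the series, on what has been measured and on what is new or still open speak of the compounds shown alone.

Compound 2 `C=CC(=O)Nc1cccc(Nc2ncnc(Nc3ccc(C(=O)Nc4ccc(C)cn4)cc3)n2)c1` holds the highest number of the two measured, giving 125000 nM in a functional assay on Raji cells (Homo sapiens) for antiproliferative activity, read by CCK-8 assay, with a stated time of 24 h; a higher number here means a weaker inhibitor, a lower number a stronger inhibitor. Compound 1 `C=CC(=O)Nc1cccc(Nc2nc(N)nc(Nc3ccc(Oc4ccccc4)cc3)n2)c1` gives 8320 nM in this assay, and the gap between the two lies beyond the scatter. Compound 3 `C=CC(=O)Nc1cccc(Nc2ncnc(Nc3ccc(C(=O)N4CCCCC4)cc3)n2)c1` keeps the framework of compound 2 and changes only the group on the carbonyl carbon: piperidin-1-yl in place of (5-methylpyridin-2-yl)amino on a carbonyl carbon. Within the data shown here, no measured pair isolates this change, so the size of the step is open; a moderate shift is expected, as a step of a 1.8-fold lower number from compound 2 to compound 3 (0.25 log units; within the scatter), tentatively toward a lower number. Compound 3 is estimated at 70000 nM in this assay, within 15000 nM to 300000 nM.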

Compound 3, half-maximal inhibitory concentration: 5140 nM
Beside the measured number, compound 3's estimate is 14-fold (1.13 log units) above it; measured number outside the range, below it.
By their numbers in this assay, from the lowest: compounds 3 and 1 (each within the scatter of the next); then compound 2.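

On a carbonyl carbon, piperidin-1-yl in place of (5-methylpyridin-2-yl)amino gives a 24-fold lower number from compound 2 to compound 3 (1.39 log units; beyond the scatter) in this assay, showing that the group at this place can move the number substantially. The change swaps an aromatic ring and a hydrogen-bond donor for a non-aromatic ring without one, so this single step cannot separate those differences. No available measurement explains the step. Open, from the compounds shown here alone, is whether a morpholin-4-yl or dimethylamino group on the same carbonyl carbon would track with piperidin-1-yl, and whether a phenylamino group would track with (5-methylpyridin-2-yl)amino.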